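Swapping a Halogen for a Methoxybenzyl Group

This account rests on a few compounds, and the source may have more. Where it says the series, first, only, none or still open, it means among the compounds named here.

Of the compounds shown here, three that share a benzyl-triazole ether arm have been tested in a functional assay on DU-145 cells (Homo sapiens) for inhibition, read by MTT assay, with a stated time of 48 h; on this read-out higher numbers stand for weaker inhibition and lower numbers for stronger inhibition. Compound 1 `O=Cc1cccc(OCc2cn(Cc3ccccc3)nn2)c1` reaches only the limit of the assay, > 50000 nM. Compound 2 `O=C1Nc2ccc(Cl)cc2/C1=C/c1cccc(OCc2cn(Cc3ccccc3)nn2)c1` gives 24200 nM, while compound 3 `O=C1Nc2cc(Br)ccc2/C1=C\c1cccc(OCc2cn(Cc3ccccc3)nn2)c1` gives 5700 nM. Of these two numbers, compound 2 holds the higher one, that is the weaker inhibition, and its gap to compound 3 lies beyond the scatter of repeated measurements.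

Compound 4 `COc1ccc(Cc2ccc3c(c2)/C(=C/c2cccc(OCc4cn(Cc5ccccc5)nn4)c2)C(=O)N3)cc1` has not yet been measured. It differs from compound 2 by 4-methoxybenzyl in place of chloro on an aromatic carbon. Among the measured compounds shown here, no two measured compounds differ from each other in a single place, so the size of such a change cannot be read from any measured pair here. The step from compound 2 to compound 4 is expected to be a 3.0-fold lower number from compound 2 to compound 4 (0.48 log units; beyond the scatter), toward a lower number, though with wide uncertainty. For compound 4 the value in this assay is estimated at 8000 nM, likely between 2000 nM and 30000 nM.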

Compound 4, half-maximal inhibitory concentration: 6700 nM
Beside the measured number, compound 4's estimate is 1.2-fold (0.08 log units) above it; measured number inside the range.
By their numbers in this assay, from the lowest: compounds 3 and 4 (each within the scatter of the next); then compound 2. At a limit, above all of these: compound 1.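

Swapping chloro for 4-methoxybenzyl on this aromatic carbon gives a 3.6-fold lower number from compound 2 to compound 4 (0.56 log units; beyond the scatter) in this assay, a modest step and the first comparison in this set that changes only one place. The position therefore tolerates a much larger group, one that brings a second six-membered aromatic ring and a hydrogen-bond acceptor, and inhibition improves rather than being lost. No measurement shown bears on why this happens.

Going by these compounds, it remains open whether the improvement depends on the added ring, the methoxy oxygen or the carbon link, and a plain benzyl, a phenyl or a methyl group on the same carbon would help separate these. On these data alone, how an amine or a carboxylic acid would read at this position also remains open.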